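Working notes: carboxymethyl in place of dimethylamino

The source may report more compounds than this note shows. Statements on the series, on what has been measured and on what is new or still open speak of the compounds shown alone.

Measured so far in a functional assay with Oryctolagus cuniculus as the target; a higher number here means a weaker inhibitor, a lower number a stronger inhibitor:
- compound 1 `COc1ccc(-c2nc(CN(C)C)sc2-c2ccc(OC)cc2)cc1` gives 96 nM
- compound 2 `COc1ccc(-c2nc(CNC(=O)C3=NNC(=O)CC3)sc2-c2ccc(OC)cc2)cc1` gives 55 nM
- compound 3 `CCOC(=O)/C=C/c1nc(-c2ccc(OC)cc2)c(-c2ccc(OC)cc2)s1` gives 20 nM

Compound 1 stands at the highest number of the three in this assay. Its nearest neighbour is compound 2, with a 1.7-fold lower number from compound 1 to compound 2 (0.24 log units; within the scatter); the furthest is compound 3, with a 4.8-fold lower number from compound 1 to compound 3 (0.68 log units; beyond the scatter).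

Compound 4 `COc1ccc(-c2nc(CCC(=O)O)sc2-c2ccc(OC)cc2)cc1` differs from compound 1 at one place: carboxymethyl in place of dimethylamino on a saturated chain carbon bound to an aromatic carbon. Both measured steps from compound 1 bear on this, since each of them also removes the dimethylamino group at the same place. Neither step raised the number; the larger change, to a carbonyl-bearing chain on the aromatic carbon, gave a 4.8-fold lower number from compound 1 to compound 3 (0.68 log units; beyond the scatter), and the change to the ring-bearing amide gave only a 1.7-fold lower number from compound 1 to compound 2 (0.24 log units; within the scatter). Compound 4 carries 2-carboxyethyl at that position, a chain with one carbonyl, so a modest step down in this assay is expected, a 2.4-fold lower number from compound 1 to compound 4 (0.38 log units; beyond the scatter). For compound 4 the estimate is 40 nM, with a range from 15 nM to 110 nM.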

Compound 4, half-maximal inhibitory concentration: < 100 nM
Compound 4: a limit, no number (the forecaster's own chance of this, stated with the estimate: 5%); the middle value does not contradict the limit.
By their numbers in this assay, from the lowest: compound 3; then compounds 2 and 1 (each within the scatter of the next).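

In this assay compound 4 gives < 100 nM as a limit and not a number. The steps linking compound 4 to compound 1, compound 2 and compound 3 therefore cannot be read. The compounds shown leave open how 2-carboxyethyl compares with (dimethylamino)methyl on this shared core.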